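The compounds below may be only part of what the source reports. "The series", "measured", "known", "first", "only" and "open" are said of these compounds alone.

Measured so far:
compound 1 `CCCn1c(=O)c2nc(-c3ccc(OC(C)=O)cc3)[nH]c2n(CCC)c1=O` — 8 nM
compound 2 `CCCn1c(=O)c2nc(-c3ccc(C(N)=O)cc3)[nH]c2n(CCC)c1=O` — 7 nM; 25 nM (2 entries)

In an assay on isolated protein for binding affinity to adenosine receptor A1 (Rattus norvegicus) (on this read-out higher numbers stand for weaker inhibition and lower numbers for stronger inhibition), compound 1 gives 8 nM, the only number shown for it; one further entry carries no single number. Compound 2 gives 7 nM; 25 nM (2 entries), see (the several entries of compound 2 in this assay, 7 nM; 25 nM (2 entries)). Compound 3 `CCCn1c(=O)c2nc(-c3ccc(S(N)(=O)=O)cc3)[nH]c2n(CCC)c1=O` differs from compound 1 by sulfamoyl in place of acetoxy on an aromatic carbon. Going by the values given here, no measured step covers this change. The expected step, a 1.9-fold higher number from compound 1 to compound 3 (0.27 log units; within the scatter), is small and within the usual scatter, with no clear direction. Compound 3 is estimated at 15 nM, in a range of 4 nM to 60 nM.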

Compound 3, inhibition constant: 8.5 nM
Beside the measured number, compound 3's estimate is 1.8-fold (0.25 log units) above it; low and high end bracket the measured number.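

In this assay, sulfamoyl in place of acetoxy on an aromatic carbon, para to a large group, gives a 1.1-fold higher number from compound 1 to compound 3 (0.03 log units; within the scatter). This change keeps the heavy-atom count and adds a hydrogen-bond donor, yet the read-out does not separate the two compounds. Compound 2 carries a third group at this position, but it gives no firm reference, because its entries differ: the several entries of compound 2 in this assay, 7 nM; 25 nM (2 entries)

On these data alone, whether this holds for a carboxylic acid, an amine or a longer chain at this position remains open. A methoxy or hydroxyl group there is also untested in the compounds shown.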